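The compounds below may be only part of what the source reports. "The series", "measured", "known", "first", "only" and "open" are said of these compounds alone.

Three compounds share a core in which two carbonyl groups hang on a hydrazine bearing a tert-butyl group. Compound 1 `CC(C)(C)N(NC(=O)c1ccccc1)C(=O)c1ccccc1F` carries a 2-fluorophenyl on one carbonyl and a plain phenyl on the other; in an assay on cells for agonist activity at ecdysone receptor (Bombyx mori), read by a luciferase reporter, with a stated time of 24 h (on this read-out lower numbers stand for an effect already at smaller amounts and higher numbers for an effect only at larger amounts of compound), compound 1 gives 309 nM. Compound 2 `CC(C)(C)N(NC(=O)c1ccc(I)cc1)C(=O)c1ccccc1Cl` gives 7.59 nM and compound 3 `Cc1ccc(C(=O)NN(C(=O)c2cc(C)cc(C)c2)C(C)(C)C)cc1` gives 12 nM, so compound 1 shows the highest number of the three, and both gaps lie beyond the usual scatter.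

Compound 4 `CC(C)(C)N(NC(=O)c1ccccc1)C(=O)C1CCCCC1` differs from compound 1 in one place: cyclohexyl in place of 2-fluorophenyl on a carbonyl carbon. Within the data shown here, no measured pair in this set shows the effect of swapping an aromatic ring for a saturated one on that carbonyl, so the expectation rests on compound 1 alone. Because compound 1 already stands at 309 nM, and the change removes the only aromatic ring on that side, the step from compound 1 to compound 4 is expected to go towards a higher number, by a 9.7-fold higher number from compound 1 to compound 4 (0.99 log units; beyond the scatter). Compound 4 is therefore estimated at 3000 nM, within a range of 500 nM to 20000 nM.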

Compound 4, half-maximal effective concentration: 46800 nM
Compound 4: middle estimate off by 16-fold (1.19 log units), on the low side; measured number above the stated range.
By their numbers in this assay, from the lowest: compounds 2 and 3 (each within the scatter of the next); then compound 1; then compound 4.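

Placing cyclohexyl in place of 2-fluorophenyl on a carbonyl carbon gives a 150-fold higher number from compound 1 to compound 4 (2.18 log units; beyond the scatter) in this assay, the first one-place comparison in this set. Both groups are six-membered carbon rings and neither has hydrogen-bond donors or acceptors, yet the number changes greatly, so this position is far from indifferent to which ring it carries. Nothing available here gives a reason for the size of this step.

The change removes the fluorine and the aromatic ring together, so the step cannot show how much each loss counts. As far as these compounds go, it also remains open how a pyridine ring, an unsubstituted cyclopentyl ring or a straight hexyl chain on that carbonyl would fare, and whether the step would be as large with a different group on the other carbonyl.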